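Aryl amide variation, compound 2 to compound 3

The source may report more compounds than this note shows. Statements on the series, on what has been measured and on what is new or still open speak of the compounds shown alone.

In an assay on MDA-MB-231 cells for binding affinity to C-X-C chemokine receptor type 4 (Homo sapiens), read by immunofluorescence and microscopy, with stated times of 10 min and 30 min (a lower number here means that less compound is needed, a higher number that more compound is needed for the effect), compound 1 `O=C(NCc1ccc(CNS(=O)(=O)c2ccccc2)cc1)c1ccc(F)cc1` gives 100 nM, and compound 2 `O=C(NCc1ccc(CNS(=O)(=O)c2ccccc2)cc1)c1ccccc1Cl` gives 10 nM. Among the measured compounds shown here, the single step, a 10-fold lower number from compound 1 to compound 2 (1.00 log units; beyond the scatter), leaves compound 2 with the lowest of the two numbers. Compound 3 `Cc1ccc(C(=O)NCc2ccc(CNS(=O)(=O)c3ccccc3)cc2)cc1` carries 4-methylphenyl in place of 2-chlorophenyl on a carbonyl carbon. For the measured compounds named here, only that one step bears on this change, and as it altered the aryl group in more than one way at once, it gives no clean read on 4-methylphenyl; a drift back toward compound 1 seems more likely than a further gain. The expected step is a 5.0-fold higher number from compound 2 to compound 3 (0.70 log units; beyond the scatter). Compound 3 is estimated at 50 nM, with a range of 15 nM to 200 nM.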

Compound 3, effective concentration (reported as EC, without a stated level of effect): 100 nM
Estimate against measurement, compound 3: 2.0-fold (0.30 log units) below; low and high end bracket the measured number.
By their numbers in this assay, from the lowest: compound 2; then compounds 1 and 3 (each within the scatter of the next).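

In this assay the change to 4-methylphenyl gives a 10-fold higher number from compound 2 to compound 3 (1.00 log units; beyond the scatter) and so the low number of compound 2 does not carry over to this group on the carbonyl carbon. Methyl in place of fluoro on an aromatic carbon gives no change at the digits printed from compound 1 to compound 3 (within the scatter) and so, of these three, only the 2-chlorophenyl amide stands apart. The 2-chlorophenyl and 4-methylphenyl groups differ in both substituent and its place, and these compounds do not separate the two. On these data alone, how a methoxy group or an amine on this aryl ring would read remains open. No supporting data bear on the reason for these steps.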